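This account rests on a few compounds, and the source may have more. Where it says the series, first, only, none or still open, it means among the compounds named here.

The compounds measured so far:
Compound 1 `OC[C@H]1O[C@@H](n2cnc3c(NCc4ccccc4)nccc32)C[C@@H]1O`: in a functional assay on EL4 cells (Mus musculus) for inhibition, tested at 100 uM (on this read-out higher numbers stand for more inhibition at the one concentration tested (going by the name of the read-out) and lower numbers for less inhibition), compound 1 gives 8%.
Compound 2 `CN(C)c1nccc2c1ncn2[C@H]1C[C@H](O)[C@@H](CO)O1`: in this assay compound 2 gives < 5%, which is a limit of the assay and not a number.
Compound 3 `OC[C@H]1O[C@@H](n2cnc3cnccc32)C[C@@H]1O`: in this assay compound 3 gives < 5%, again a limit of the assay and not a number.

Compound 3 therefore sits at the floor of what this assay reports, as is seen in the limit of < 5% in this assay, at which 2 of the 3 values shown sit. Compound 4 `OC[C@H]1O[C@@H](n2cnc3c(SCc4ccccc4)nccc32)C[C@@H]1O` differs from it by benzylsulfanyl in place of hydrogen on an aromatic carbon. The measured step that bears most directly on this is a number at least 3 percentage points lower from compound 1 to compound 3 (that floor lies within the scatter), where removal of benzylamino took the number down to the limit. The step of a number at least 3 percentage points lower from compound 1 to compound 2 (that floor lies within the scatter) likewise ended at the limit, and the step that the two limits leave unreadable from compound 2 to compound 3 cannot be read. Putting benzylsulfanyl onto that carbon is thus expected to move compound 4 upward in this assay only slightly, if at all. The step of a number at least 2 percentage points higher from compound 3 to compound 4 (that floor lies within the scatter) is expected to stay within the scatter. Compound 4 is estimated at 7%, between 0% and 18%, with a fair chance that only a limit is reported.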

Compound 4, a percentage reported as inhibition, at one concentration (the size of the read-out at that concentration, not a potency): 11%
Compound 4: the middle estimate sits 4 percentage points below what was measured; the measured number falls inside the stated range.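

With benzylsulfanyl on this aromatic carbon, this assay shows a number at least 6 percentage points higher from compound 3 to compound 4 (that floor lies within the scatter), and putting the same group in place of dimethylamino gives a number at least 6 percentage points higher from compound 2 to compound 4 (that floor lies within the scatter). Exchanging benzylamino for benzylsulfanyl, a change in the atom that links the benzyl group to the core, gives a number 3 percentage points higher from compound 1 to compound 4 (within the scatter), so the two groups cannot be told apart in this read-out. Only compound 1 and compound 4, which both carry a benzyl group on this carbon, give a number, while compound 2 and compound 3 give only a limit: the limit of < 5% in this assay, at which 2 of the 4 values shown sit.

From the compounds shown here alone, it remains open whether a longer chain such as phenethylamino on this carbon would give a number clearly beyond the scatter. Also open, going by these compounds, is whether a methylsulfanyl group, which lacks the benzene ring, would still give a number.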